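Halogen Swap on a Weakly Cytotoxic Diterpenoid Acid

This account rests on a few compounds, and the source may have more. Where it says the series, first, only, none or still open, it means among the compounds named here.

Compound 1 `CC(CC[C@H]1/C(=C/c2ccc([N+](=O)[O-])cc2)CC[C@H]2C(C)(C)CCC[C@]12C)CC(=O)O` gives 169000 nM in a functional assay on K562 cells (Homo sapiens) for cytotoxicity, read by MTT assay, with a stated time of 72 h; a lower number here means a stronger inhibitor, a higher number a weaker inhibitor. Compound 2 `CC(CC[C@H]1/C(=C/c2ccc(Cl)cc2)CC[C@H]2C(C)(C)CCC[C@]12C)CC(=O)O` reaches only the assay's limit in this assay, > 200000 nM. The step of an at least 1.1-fold higher number from compound 1 to compound 2 (0.07 log units; that floor lies within the scatter) rests on the limit of > 200000 nM in this assay, at which 1 of the 2 values shown sits, and is bounded rather than measured. Compound 3 `CC(CC[C@H]1/C(=C/c2ccc(Br)cc2)CC[C@H]2C(C)(C)CCC[C@]12C)CC(=O)O` differs from compound 2 by bromo in place of chloro on an aromatic carbon. Among the measured compounds shown here, the one measured step, nitro to chloro on that aromatic carbon, stayed within the scatter, and bromo and chloro are each a single heavy atom, so no move beyond the scatter is expected in this assay. Compound 3 is expected to give about 250000 nM, between 120000 nM and 600000 nM. The expected step is a step that the limit leaves unreadable from compound 2 to compound 3.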

Compound 3, half-maximal inhibitory concentration: > 200000 nM
Compound 3 was reported as a limit; the forecaster's own chance of this, stated with the estimate: 70%; the middle value lies beyond the limit too.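

In this assay, compound 3 stands at a limit, as compound 2 does, so the step between them cannot be read and the 4-chlorophenyl to 4-bromophenyl change stays unsized. Bromo in place of nitro on that aromatic carbon gives an at least 1.1-fold higher number from compound 1 to compound 3 (0.07 log units; that floor lies within the scatter), a bounded reading like the one chloro gave. Two of the three compounds now sit at a limit: the limit of > 200000 nM in this assay, at which 2 of the 3 values shown sit.

The compounds shown leave open how far compound 2 and compound 3 truly lie from compound 1, and whether an amine or a hydroxyl on that aromatic carbon would give a number clear of the limit.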